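The compounds below may be only part of what the source reports. "The series", "measured", "known", "first", "only" and "open" are said of these compounds alone.

Measured so far: compound 1, `CCc1ccccc1-n1nncc1CN1C(=O)C2(C(C#N)=C(N)Oc3c(N)cc4nc5ccccc5nc4c32)c2ccccc21`, at 17900 nM; compound 2, `CC(=O)Nc1ccc(-n2nncc2CN2C(=O)C3(C(C#N)=C(N)Oc4c(N)cc5nc6ccccc6nc5c43)c3ccccc32)cc1`, at > 50000 nM.

In a functional assay on HepG2 cells (Homo sapiens) for antiproliferative activity, read by MTT assay, with a stated time of 48 h (a higher number here means a weaker inhibitor, a lower number a stronger inhibitor), compound 1 gives 17900 nM. In this assay compound 2 gives > 50000 nM, which is a limit of the assay and not a number (the limit of > 50000 nM in this assay, at which 1 of the 2 values shown sits). Compound 2 therefore stands at the weak end of the two values. Among the measured compounds shown here, the only measured step is an at least 2.7-fold higher number from compound 1 to compound 2 (0.44 log units; beyond the scatter), which replaced 2-ethylphenyl. Compound 3 is `COc1ccccc1-n1nncc1CN1C(=O)C2(C(C#N)=C(N)Oc3c(N)cc4nc5ccccc5nc4c32)c2ccccc21`; the change is 2-methoxyphenyl in place of 4-acetamidophenyl on an aromatic nitrogen. This restores a phenyl carrying one small group, as in compound 1, so a return toward the value of compound 1 is expected: a step of an at least 2.5-fold lower number from compound 2 to compound 3 (0.39 log units; beyond the scatter). Compound 3 is estimated at 20000 nM, within 7000 nM to 55000 nM.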

Compound 3, half-maximal inhibitory concentration: > 50000 nM
Compound 3 ended at the assay's limit; the forecaster's own chance of this, stated with the estimate: 30%; middle value at least 2.5-fold (0.39 log units) from the limit.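

Methoxy in place of ethyl on an aromatic carbon gives an at least 2.7-fold higher number from compound 1 to compound 3 (0.44 log units; beyond the scatter) in this assay, so a phenyl carrying one small group does not by itself keep the activity of compound 1; the identity of that group matters. Compound 2 and compound 3 both sit at a limit of the assay, not at a number, so the step between them cannot be read: the limit of > 50000 nM in this assay, at which 2 of the 3 values shown sit.

Still open, going by these compounds, is whether an amine or a propyl chain in place of ethyl would keep or improve the activity of compound 1. On these data alone, how weak compound 2 and compound 3 really are also remains unknown.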